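This account rests on a few compounds, and the source may have more. Where it says the series, first, only, none or still open, it means among the compounds named here.

Measured so far in a functional assay on HepG2 cells (Homo sapiens) for cytotoxicity, read by MTT assay, with a stated time of 48 h (a lower number here means a stronger inhibitor, a higher number a weaker inhibitor), are two compounds:

compound 1 `Nc1ccccc1Nc1n[n+]([O-])c2ccccc2[n+]1[O-]` gives 17400 nM
compound 2 `[O-][n+]1nc(NC2CC2)[n+]([O-])c2ccccc21` gives 13300 nM

These two values lie within the usual scatter of each other, so compound 2 stands level with compound 1 on the numbers shown. Compound 3 `[O-][n+]1nc(Nc2ccccc2)[n+]([O-])c2ccccc21` is still unmeasured. It has phenyl in place of cyclopropyl on a nitrogen on an aromatic ring. Going by the values given here, no measured pair shows this change alone, so no step beyond the scatter is expected in this assay and neither direction is favoured. The estimate means an expected step of a 1.1-fold higher number from compound 2 to compound 3 (0.02 log units; within the scatter) that stays within the scatter. Compound 3 is estimated at 14000 nM with an expected range from 6000 nM to 32000 nM in this measurement.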

Compound 3, half-maximal inhibitory concentration: 15000 nM
For compound 3 the middle estimate is 1.1-fold (0.03 log units) below the measured one, within the range that was stated.
By their numbers in this assay, from the lowest: compounds 2, 3 and 1 (each within the scatter of the next).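

In this assay phenyl in place of cyclopropyl on a nitrogen on an aromatic ring gives a 1.1-fold higher number from compound 2 to compound 3 (0.05 log units; within the scatter) and so does not separate the two compounds. Hydrogen in place of amino on an aromatic carbon gives a 1.2-fold lower number from compound 1 to compound 3 (0.06 log units; within the scatter) and likewise leaves the two compounds level. Nothing available bears on why these steps are so small. From the compounds shown here alone, whether a carboxylic acid or a longer chain on that nitrogen would give a step beyond the scatter remains open.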